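Moving the methoxy and trifluoromethyl groups around the phenyl ring

The compounds below may be only part of what the source reports. "The series", "measured", "known", "first", "only" and "open" are said of these compounds alone.

Compound 1, `COc1ccc(Nc2ncc(C(F)(F)F)c(N3Cc4cccc(N(C)S(C)(=O)=O)c4C3)n2)cc1C(F)(F)F`, stands at the weak end of what has been measured: in a functional assay on OVCAR-3 cells (Homo sapiens) for antiproliferative activity, read by spectrophotometry, with a stated time of 2 days (on this read-out lower numbers stand for stronger inhibition of growth and higher numbers for weaker inhibition of growth), compound 1 gives > 30000 nM, which is a limit of the assay rather than a number. Compound 2, `Cc1cc(F)ccc1Nc1ncc(C(F)(F)F)c(N2Cc3cccc(N(C)S(C)(=O)=O)c3C2)n1`, gives > 30000 nM in this assay, also a limit. Compound 3, `COc1cc(Nc2ncc(C(F)(F)F)c(N3Cc4cccc(N(C)S(C)(=O)=O)c4C3)n2)cc(OC)c1`, gives 630 nM in this assay. Two of the three values thus sit at the limit of > 30000 nM in this assay, at which 2 of the 3 values shown sit.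

Compound 4, `COc1cc(Nc2ncc(C(F)(F)F)c(N3Cc4cccc(N(C)S(C)(=O)=O)c4C3)n2)cc(C(F)(F)F)c1`, is not yet measured and differs from compound 1 in one place: 3-methoxy-5-(trifluoromethyl)phenyl in place of 4-methoxy-3-(trifluoromethyl)phenyl on a nitrogen on an aromatic ring.

For the measured compounds named here, two measured steps bear on this change. The step of an at least 47-fold lower number from compound 1 to compound 3 (1.67 log units; beyond the scatter) shows that putting two groups on the 3,5-positions of the phenyl brings the number far down from the limit. The step that the two limits leave unreadable from compound 1 to compound 2 gives no guidance. Compound 4 shares the 3,5-pattern of compound 3 while keeping the trifluoromethyl of compound 1, so a clear fall from the limit is expected. Compound 4 is expected to give 2500 nM, within 500 nM to 20000 nM. That estimate corresponds to an expected step of an at least 12-fold lower number from compound 1 to compound 4 (1.07 log units; beyond the scatter).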

Compound 4, concentration for 50% growth inhibition: > 30000 nM
Compound 4: a limit, no number; the forecaster's own chance of this, stated with the estimate: 25%; middle value at least 12-fold (1.07 log units) from the limit.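

Replacing one methoxy of the 3,5-dimethoxyphenyl with trifluoromethyl undoes the activity of compound 3 in this assay, with an at least 47-fold higher number from compound 3 to compound 4 (1.67 log units; beyond the scatter). For this pair, then, the arrangement of the two groups on the phenyl ring is not enough on its own, and the identity of the second group matters as well. Compounds 1, 2 and 4 each carry only a limit of the assay, so the steps among them cannot be read and their phenyl groups cannot be ranked: the limit of > 30000 nM in this assay, at which 3 of the 4 values shown sit.

The compounds shown leave open which feature of the second methoxy counts, since only trifluoromethyl has taken its place. An ethoxy, a hydroxyl or an amine on that aromatic carbon could show whether any other group keeps the activity of compound 3.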